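This account rests on a few compounds, and the source may have more. Where it says the series, first, only, none or still open, it means among the compounds named here.

In an ADME assay on GES1 cells (Homo sapiens) for inhibition, read by MTT assay, with a stated time of 72 h (a higher number here means a weaker inhibitor, a lower number a stronger inhibitor), compound 1 (`Cc1cc(Nc2cc(-c3ccccc3)[nH]n2)n2nc(SCc3ccc(F)cc3)nc2n1`) gives 35500 nM and compound 2 (`Cc1cc(Nc2cc(-c3ccccc3)[nH]n2)n2nc(SCc3ccc(Cl)cc3)nc2n1`) gives 31800 nM on the same scale. Compound 2 therefore stands level with compound 1, the two values lying within the scatter of each other. Compound 3 (`C#CCSc1nc2nc(C)cc(Nc3cc(-c4ccccc4)[nH]n3)n2n1`) has not yet been measured. It departs from compound 2 as follows: ethynyl in place of 4-chlorophenyl on a saturated chain carbon bound to a sulfur. In words, ethynyl stands in place of 4-chlorophenyl on a saturated chain carbon bound to a sulfur, so 4-chlorobenzyl becomes propargyl. For the measured compounds named here, the only measured step is a 1.1-fold lower number from compound 1 to compound 2 (0.05 log units; within the scatter), a chloro for fluoro swap that leaves the aromatic ring in place, so it says little about this change. Going by the values given here, no measured step removes that ring. A modest rise is therefore expected, with wide uncertainty: the expected step is a 1.3-fold higher number from compound 2 to compound 3 (0.12 log units; within the scatter) in this assay. For compound 3 the estimated value is 42000 nM, within an expected range of 16000 nM to 100000 nM.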

Compound 3, half-maximal inhibitory concentration: 45700 nM
For compound 3 the middle estimate is 1.1-fold (0.04 log units) below the measured one; the range from low to high includes it.
By their numbers in this assay, from the lowest: compounds 2, 1 and 3 (each within the scatter of the next).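

In this assay, the step with ethynyl in place of 4-chlorophenyl on a saturated chain carbon bound to a sulfur is a 1.4-fold higher number from compound 2 to compound 3 (0.16 log units; within the scatter) and the step with ethynyl in place of 4-fluorophenyl at that place is a 1.3-fold higher number from compound 1 to compound 3 (0.11 log units; within the scatter) here. The earlier compounds shown here differed only in the halogen on the aromatic ring, whereas these steps show that the whole ring can give way to ethynyl with the number staying within the scatter. No measurement at hand bears on why this is so.

The compounds shown leave open whether any group at this place moves the number beyond the scatter. A carboxylic acid, an amine or a longer alkyl chain on that saturated chain carbon could test this, as the three groups shown give no such step.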